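Swapping the amine arm: expected solubility of compound 4

This account rests on a few compounds, and the source may have more. Where it says the series, first, only, none or still open, it means among the compounds named here.

Compound 1 `COc1ccc2[nH]c(C(=O)N3CC(=O)N(Cc4ccccc4)[C@@H](CCc4ccccc4)C3)cc2c1`: 4400 nM
Compound 2 `COc1ccc2[nH]c(C(=O)N3CC(=O)N(Cc4ccccc4)[C@@H](CN4CCC(OC)CC4)C3)cc2c1`: > 25000 nM
Compound 3 `COc1ccc2[nH]c(C(=O)N3CC(=O)N(Cc4ccccc4)[C@@H](CN4CCCC4)C3)cc2c1`: > 25000 nM

In a physicochemical assay for solubility, read by spectrophotometry, in phosphate buffer, with a stated time of 2 h, at pH 7.4 (on this read-out higher numbers stand for higher solubility and lower numbers for lower solubility), compound 1 gives 4400 nM. Compound 2 reaches only the upper limit of the method, > 25000 nM. Compound 3 likewise reaches only that limit, > 25000 nM, so where it stands is known only as a floor (the limit of > 25000 nM in this assay, at which 2 of the 3 values shown sit). Compound 4 `COc1ccc2[nH]c(C(=O)N3CC(=O)N(Cc4ccccc4)[C@@H](N4[C@H](C)CCC[C@@H]4C)C3)cc2c1` is not yet measured; it differs from compound 3 by 2,6-dimethylpiperidin-1-yl in place of (pyrrolidin-1-yl)methyl on a saturated ring carbon. Within the data shown here, two measured steps bear on it: an at least 5.6-fold higher number from compound 1 to compound 3 (0.75 log units; beyond the scatter) and an at least 5.6-fold higher number from compound 1 to compound 2 (0.75 log units; beyond the scatter), both beyond the scatter, while a step that the two limits leave unreadable from compound 2 to compound 3. Compound 4 keeps a saturated ring with one nitrogen, so no step beyond the scatter is expected in this assay: a number no higher from compound 3 to compound 4 (the limit leaves the size open). Compound 4 is therefore estimated at 25000 nM (range 6000 nM to 60000 nM), most likely again at the limit.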

Compound 4, solubility: 100000 nM
Beside the measured number, compound 4's estimate is 4.0-fold (0.60 log units) below it; measured number above the stated range.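

In this assay, 2,6-dimethylpiperidin-1-yl in place of phenethyl on this saturated ring carbon gives a 23-fold higher number from compound 1 to compound 4 (1.36 log units; beyond the scatter). Among these compounds, this is the first step to an amine-bearing compound at this position whose size can be read. The steps to compound 4 from compound 2 and compound 3 cannot be read, as both of those compounds sit at a limit: the limit of > 25000 nM in this assay, at which 2 of the 4 values shown sit.

Going by these compounds, it remains open whether the two methyl groups or the ring nitrogen's direct attachment to this carbon matters more. A plain piperidin-1-yl here, or the same 2,6-dimethylpiperidin-1-yl on a methylene link, would separate the two.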